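The source may hold more compounds than are shown below. What is called first, only, known or untested is meant among the compounds shown, and "the series" means these compounds.

Measured in an ADME assay on L1210/0 cells (Mus musculus) for cytotoxicity, with a stated time of 48 h; on this read-out lower numbers stand for stronger inhibition and higher numbers for weaker inhibition:
- Compound 1 `OC[C@@H]1C[C@H](Cn2cnc3c(Cl)ncnc32)c2c(-c3ccccc3)nnc(-c3ccccc3)c21`: > 200000 nM
- Compound 2 `Nc1nc2c(nc(I)n2COCCO)c(=O)[nH]1`: 111000 nM

The entry for compound 1, > 200000 nM, is a limit of the assay and not a number. Among the measured compounds shown here, compound 2, at 111000 nM, therefore holds the only true number in this assay so far.

Compound 3 `Nc1nc2c(nc(Cl)n2COCCO)c(=O)[nH]1` keeps the rest of compound 2 and carries chloro in place of iodo on an aromatic carbon, between two ring nitrogen atoms (chloro in place of iodo on an aromatic carbon). For the measured compounds named here, no measured pair shows what such a swap does here, so the expectation rests on compound 2 at 111000 nM, with no shift beyond the usual scatter foreseen in this assay. The expected change is a 1.1-fold higher number from compound 2 to compound 3 (0.03 log units; within the scatter). Compound 3 is estimated at 120000 nM, with an expected range from 50000 nM to 280000 nM.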

Compound 3, half-maximal inhibitory concentration: > 200000 nM
Compound 3: only a limit was reported; the forecaster's own chance of this, stated with the estimate: 35%; middle value at least 1.6-fold (0.22 log units) away from the limit.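

In this assay compound 3 gives > 200000 nM, which is a limit of the assay and not a number. Among the compounds shown here, this is the first comparison in one place, on the aromatic carbon between two ring nitrogen atoms, and it reads as an at least 1.8-fold higher number from compound 2 to compound 3 (0.25 log units; that floor lies within the scatter). With that floor inside the scatter, the pair does not establish that chloro and iodo differ here; it shows only that the chloro compound gives no true number, and the full size of the step stays hidden, with most values now sitting at one ceiling: the limit of > 200000 nM in this assay, at which 2 of the 3 values shown sit.

The compounds shown leave open whether bromo, an amine or a methyl group on this carbon would give a true number in this read-out. They also leave open what a longer chain in place of the (2-hydroxyethoxy)methyl group would do.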